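The compounds below may be only part of what the source reports. "The series", "measured", "known", "first", "only" and "open" are said of these compounds alone.

Compound 1 `CC(C)(C)c1ccc(C(=O)NCc2ccc(NC(=O)C(F)(F)F)cc2Cl)cc1`: 14 nM
Compound 2 `CC(C)(C)c1ccc(C(=O)NCc2ccc(N)cc2Cl)cc1`: 46 nM

The two measured compounds share one core and differ only at the nitrogen on the aromatic ring. In an assay on HeLa cells with Bile acid receptor (Homo sapiens) as the target, read by a luciferase reporter, with a stated time of 24 h (on this read-out higher numbers stand for an effect only at larger amounts of compound and lower numbers for an effect already at smaller amounts), compound 1 gives 14 nM, while compound 2 gives 46 nM. Among the measured compounds shown here, the single known step is a 3.3-fold higher number from compound 1 to compound 2 (0.52 log units; beyond the scatter). For the measured compounds named here, compound 2 therefore stands with the higher of the two numbers in this assay, and its only neighbour, compound 1, lies beyond the scatter from it.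

Compound 3 `CC(C)(C)c1ccc(C(=O)NCc2ccc(C(=O)O)cc2Cl)cc1` has not yet been measured. Relative to compound 2 the change is carboxy in place of amino on an aromatic carbon. Going by the values given here, no measured step touches a carboxy group, so the one known step bears on this change only loosely: it shows that the number at this position moved beyond the scatter once when the amino group was altered, without telling the direction for a carboxy. The expected step of a 1.7-fold higher number from compound 2 to compound 3 (0.24 log units; within the scatter) is therefore uncertain in sign, with a wide range. Compound 3 is estimated to give 80 nM in this assay, expected between 15 nM and 400 nM.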

Compound 3, half-maximal effective concentration: 7500 nM
Compound 3: middle estimate off by 94-fold (1.97 log units), on the low side; the whole stated range lies below it.
By their numbers in this assay, from the lowest: compound 1; then compound 2; then compound 3.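

In this assay, among the compounds shown here, putting carboxy in place of amino on this aromatic carbon gives a 160-fold higher number from compound 2 to compound 3 (2.21 log units; beyond the scatter), a large step where the only earlier change at this position, a 3.3-fold higher number from compound 1 to compound 2 (0.52 log units; beyond the scatter), was modest. Against the ((trifluoromethyl)carbonyl)amino group the same position shows a 540-fold higher number from compound 1 to compound 3 (2.73 log units; beyond the scatter), so among these three compounds the two groups attached through nitrogen lie much closer to each other than either lies to the carboxy group, which is attached through carbon, and the position proves far from indifferent to what it carries. Nothing given here offers a cause for the size of these steps.

The compounds shown leave open whether the much higher number belongs to the carboxy group in particular or to groups attached through carbon more widely, a question that a methyl ester, a primary carboxamide or a nitrile at this position would address. They also leave open whether other groups attached through nitrogen, such as an acetamide or a methanesulfonamide, would stay close to compound 1 and compound 2 in this assay.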